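Swapping the Sulfonyl Aryl Group and Liver Clearance

This account rests on a few compounds, and the source may have more. Where it says the series, first, only, none or still open, it means among the compounds named here.

Compound 1, `O=S(=O)(c1cc(Cl)cc(Cl)c1)c1cnc2cc(F)ccc2c1-c1ccc(Cl)cc1`: 0.13 mL/min
Compound 2, `O=S(=O)(c1cccc(F)c1)c1cnc2cc(F)ccc2c1-c1ccc(Cl)cc1`: 0.98 mL/min
Compound 3, `O=S(=O)(c1cc(Cl)cc(Cl)c1)c1cnc2cc(F)ccc2c1-c1ccc(F)cc1`: 0.18 mL/min

All three compounds were tested in an ADME assay on microsomes from liver (Homo sapiens) for metabolic stability, tested at 2.5 uM (a lower number here means slower removal, a higher number faster removal of the compound), and all share the same quinoline-type core carrying a sulfonyl group. Compound 1 and compound 2 differ in one place only: 3-fluorophenyl in place of 3,5-dichlorophenyl on a sulfonyl sulfur. This change produced a 7.5-fold higher number from compound 1 to compound 2 (0.88 log units; beyond the scatter), so the compound with the smaller fluorinated ring on the sulfonyl sulfur is removed faster in this assay.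

Compound 1 and compound 3 differ only in their cores: fluoro in place of chloro on an aromatic carbon. That change gave a 1.4-fold higher number from compound 1 to compound 3 (0.14 log units; within the scatter), a difference too small to be told apart from repeat measurements. The values of compound 2 and compound 3 show compound 2 with the higher number, with no direct single-step comparison between them.

Compound 4, `O=S(=O)(c1cccc(F)c1)c1cnc2cc(F)ccc2c1-c1ccc(F)cc1`, has not yet been measured in this assay. It differs from compound 3 by 3-fluorophenyl in place of 3,5-dichlorophenyl on a sulfonyl sulfur. The place of this change is described in exactly the same words as for the change from compound 1 to compound 2, so it is the same change made on the fluorinated core rather than the chlorinated one.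

Going by the values given here, because the one measured instance of this change is a 7.5-fold higher number from compound 1 to compound 2 (0.88 log units; beyond the scatter), compound 4 is expected to show a step of about a 6.7-fold higher number from compound 3 to compound 4 (0.82 log units; beyond the scatter). Compound 4 is therefore estimated at roughly 1.2 mL/min, with a likely range from 0.5 mL/min to 2.8 mL/min.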

Compound 4, intrinsic clearance in a liver preparation (reported as CLH), per the amount of preparation that the assay uses: 0.11 mL/min
Beside the measured number, compound 4's estimate is 11-fold (1.04 log units) above it; the whole stated range lies above it.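

In this assay, putting 3-fluorophenyl in place of 3,5-dichlorophenyl on the sulfonyl sulfur gave a 1.6-fold lower number from compound 3 to compound 4 (0.21 log units; within the scatter), so the clear step seen on the core of compound 1 did not carry over to the core of compound 3: the same change on two cores in this assay, a 7.5-fold higher number (0.88 log units; beyond the scatter) from compound 1 to compound 2 and a 1.6-fold lower number (0.21 log units; within the scatter) from compound 3 to compound 4, 12-fold (1.09 log units) apart, beyond the scatter of two such steps. The other change, fluoro in place of chloro on an aromatic carbon, gave an 8.9-fold lower number from compound 2 to compound 4 (0.95 log units; beyond the scatter), so it too behaved differently once the group on the sulfonyl sulfur was different: the same change on two cores in this assay, a 1.4-fold higher number (0.14 log units; within the scatter) from compound 1 to compound 3 and an 8.9-fold lower number (0.95 log units; beyond the scatter) from compound 2 to compound 4, 12-fold (1.09 log units) apart, beyond the scatter of two such steps. Among these compounds, then, the size of a step depends on the rest of the molecule, but both gaps come from the same four compounds and both involve compound 2, at 0.98 mL/min, so they amount to a single observation that shows neither why the steps differ nor whether the same would hold elsewhere in the series.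

The compounds shown leave open how a plain phenyl ring or a morpholine on the sulfonyl sulfur would behave on either core. They also leave open whether a methoxy group in place of the halogen on the aromatic carbon would give steps that carry from one core to another.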